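Chloro in Place of Nitro: Expected Growth Inhibition

A few compounds are considered here, and "the series" means these few. Any claim that something is new, unique, unknown or untested is made for them only; others in the source may bear on it.

Compound 1 `COc1ccc(/C=N\NC(=S)NC(C)(C)CCC[C@](C)(O)[C@@H]2CC=C(C)CC2)cc1` gives 22100 nM in a functional assay on UACC-62 cells (Homo sapiens) for cytotoxicity, read by sulforhodamine B assay; a higher number here means a weaker inhibitor of growth, a lower number a stronger inhibitor of growth. Compound 2 `CC1=CC[C@@H]([C@@](C)(O)CCCC(C)(C)NC(=S)N/N=C\c2ccc(N(C)C)cc2)CC1` reaches only the assay limit of > 100000 nM in this assay. Compound 3 `CC1=CC[C@@H]([C@@](C)(O)CCCC(C)(C)NC(=S)N/N=C\c2ccccc2[N+](=O)[O-])CC1` gives 16600 nM in this assay.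

Compound 3 has the lowest of the two numbers; its nearest neighbour is compound 1, and a 1.3-fold lower number from compound 1 to compound 3 (0.12 log units; within the scatter), so these two cannot be told apart. Compound 4 `CC1=CC[C@@H]([C@@](C)(O)CCCC(C)(C)NC(=S)N/N=C\c2ccccc2Cl)CC1` differs from compound 3 by chloro in place of nitro on an aromatic carbon. The measured steps that change the aromatic ring, an at least 4.5-fold higher number from compound 1 to compound 2 (0.65 log units; beyond the scatter) and an at least 6.0-fold lower number from compound 2 to compound 3 (0.77 log units; beyond the scatter), involve a limit and none exchanges nitro for chloro. The change in this assay from compound 3 to compound 4 is therefore expected to be a 1.2-fold higher number from compound 3 to compound 4 (0.08 log units; within the scatter), within the scatter. Compound 4 is estimated at 20000 nM, between 7000 nM and 60000 nM.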

Compound 4, concentration for total growth inhibition: > 100000 nM
Compound 4: only a limit was reported; the forecaster's own chance of this, stated with the estimate: 15%; middle value at least 5.0-fold (0.69 log units) from the limit.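

In this assay, chloro in place of nitro on this aromatic carbon gives an at least 6.0-fold higher number from compound 3 to compound 4 (0.77 log units; beyond the scatter), so a change at this one position, with the rest of the molecule untouched, can separate measurable growth inhibition from none seen up to the limit. 2-Chlorophenyl in place of 4-methoxyphenyl gives an at least 4.5-fold higher number from compound 1 to compound 4 (0.65 log units; beyond the scatter), whereas compound 3 and compound 1 could not be told apart. The step from compound 2 to compound 4 cannot be read because both stop at the same limit: the limit of > 100000 nM in this assay, at which 2 of the 4 values shown sit.

From the compounds shown here alone, compound 4 gives only a limit, so the full size of its steps stays open. Going by these compounds, whether an amine or a nitrile at this position would match nitro also stays open.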